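This account rests on a few compounds, and the source may have more. Where it says the series, first, only, none or still open, it means among the compounds named here.

Measured compounds in an ADME assay on HCT-116 cells (Homo sapiens) for cytotoxicity, read by CellTiter-Glo, with a stated time of 72 h; on this read-out higher numbers stand for weaker inhibition and lower numbers for stronger inhibition:
- compound 1 `CC1CCN(C2CCN(S(=O)(=O)c3ccc(C(C)(C)C)cc3)CC2)CC1` sits at the limit > 5000 nM; this is a limit of the assay, not a number.
- compound 2 `CCc1ccc(S(=O)(=O)N2CCC(N3CCC(C)CC3)CC2)cc1` sits at the limit > 5000 nM; again a limit.
- compound 3 `CCCCOc1ccc(S(=O)(=O)N2CCC(N3CCC(C)CC3)CC2)cc1` sits at the limit > 5000 nM; again a limit.

Compound 2 therefore stands only as a limit, and the two other values shown are limits too, (the limit of > 5000 nM in this assay, at which 3 of the 3 values shown sit). The steps among the measured compounds are all blind for that reason: a step that the two limits leave unreadable from compound 1 to compound 2, a step that the two limits leave unreadable from compound 1 to compound 3 and a step that the two limits leave unreadable from compound 2 to compound 3, each an exchange of one group on an aromatic carbon, give no readable size.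

Compound 4 `CC1CCN(C2CCN(S(=O)(=O)c3cc(Cl)cc(Cl)c3)CC2)CC1` is not yet measured. It differs from compound 2 by 3,5-dichlorophenyl in place of 4-ethylphenyl on a sulfonyl sulfur. Among the compounds with values here, no measured step bears on this change: the three aryl variations seen so far all stay at the limit, so nothing shows whether a halogenated aryl group moves cytotoxicity, in either direction, beyond the scatter. The working expectation is that compound 4 also stays at or near the limit, with an estimated 8000 nM (range 3000 nM to 30000 nM), which as an expected step from compound 2 means a step that the limit leaves unreadable from compound 2 to compound 4.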

Compound 4, half-maximal inhibitory concentration: > 5000 nM
Compound 4: a limit, no number; the forecaster's own chance of this, stated with the estimate: 75%; the middle value does not contradict the limit.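

Within the data shown here, compound 2 and compound 4 both stand only as limits, so the step between them cannot be read and no new step emerges: the limit of > 5000 nM in this assay, at which 4 of the 4 values shown sit. The compounds shown leave open whether any aryl group on the sulfonyl sulfur gives a readable number.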